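From Trifluoromethyl to Ethoxycarbonyl: a Step Without a Yardstick

The source may hold more compounds than are shown below. What is called first, only, known or untested is meant among the compounds shown, and "the series" means these compounds.

Compound 1, `CCOc1cccc(N/N=C2\CCC(C)n3c2ncc(C(=O)O)c3=O)c1`, gives in a functional assay on the whole organism for inhibition, with Rattus norvegicus as the target (a higher number here means that more compound is needed for the effect, a lower number that less compound is needed), a value of > 1000 umol/kg, which is a limit of the assay rather than a number.
Compound 2, `CC1CC/C(=N\Nc2cccc(C(F)(F)F)c2)c2ncc(C(=O)O)c(=O)n21`, gives in this assay a value of > 1000 umol/kg, again a limit of the assay rather than a number.

The step between these two compounds is a step that the two limits leave unreadable from compound 1 to compound 2. All the evidence on measured steps comes down to the limit of > 1000 umol/kg in this assay, at which 2 of the 2 values shown sit. Within the data shown here, compound 2 therefore stands at the limit of this assay, without a number of its own, and its one neighbour stands at the same limit.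

Compound 3, `CCOC(=O)c1cccc(N/N=C2\CCC(C)n3c2ncc(C(=O)O)c3=O)c1`, differs from compound 2 by ethoxycarbonyl in place of trifluoromethyl on an aromatic carbon. Among the measured compounds shown here, no measured step bears on this change: the single step available, from compound 1 to compound 2, is unreadable, and both values sit at the limit. A step beyond the scatter in either direction in this assay is not expected, and a limit is again the most likely report.

Compound 3 is expected to give about 2000 umol/kg, within a range from 600 umol/kg to 10000 umol/kg. The step this estimate means is expected to be a step that the limit leaves unreadable from compound 2 to compound 3.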

Compound 3, dose for 50% inhibition: > 100 umol/kg
Compound 3 was reported as a limit; the forecaster's own chance of this, stated with the estimate: 85%; the middle value lies beyond the limit too.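

In this assay compound 3 gives > 100 umol/kg, which is a limit of the assay and not a number. Among these compounds, its steps from compound 1 and from compound 2 cannot be read, so no new step emerges. The compounds shown leave open how ethoxy, trifluoromethyl and ethoxycarbonyl compare in this assay, as none of the three compounds has a number of its own.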